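The source may report more compounds than this note shows. Statements on the series, on what has been measured and on what is new or still open speak of the compounds shown alone.

Of the compounds shown here, two of a shared core have been measured in a functional assay on MDA-MB-231 cells (Homo sapiens) for inhibition, read by MTT assay, with a stated time of 72 h; a lower number here means a stronger inhibitor, a higher number a weaker inhibitor. Compound 1 `C=CC(=O)Nc1cccc(NC(=O)CSc2nc(Nc3ccccc3C)c3ccccc3n2)c1` gives 20400 nM in this assay. Compound 2 `C=CC(=O)Nc1cccc(NC(=O)CSc2nc(Nc3ccc(C(F)(F)F)cc3)c3ccccc3n2)c1` gives 11500 nM in this assay. Among the compounds with values here, the single change between them, 4-(trifluoromethyl)phenyl in place of 2-methylphenyl on a nitrogen on an aromatic ring, gives a 1.8-fold lower number from compound 1 to compound 2 (0.25 log units; within the scatter), so the two numbers cannot be told apart with confidence. Compound 2 therefore holds the lower of the two numbers, yet stands within the usual scatter of compound 1.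

Compound 3 `C=CC(=O)Nc1cccc(NC(=O)CSc2nc(Nc3ccc(F)c(Cl)c3)c3ccccc3n2)c1` carries the change (3-chloro-4-fluorophenyl in place of 4-(trifluoromethyl)phenyl on a nitrogen on an aromatic ring), with the rest of the molecule kept as in compound 2. Within the data shown here, the only measured step that touches this position, the one from compound 1 to compound 2, swapped one substituted phenyl ring for another on the same nitrogen and stayed within the scatter. With no other evidence, the swap to a 3-chloro-4-fluorophenyl ring is expected to leave the number roughly where compound 2 sits, as a step of a 1.0-fold higher number from compound 2 to compound 3 (0.02 log units; within the scatter). For compound 3 the expected value in this assay is 12000 nM, estimated to lie between 5000 nM and 30000 nM.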

Compound 3, half-maximal inhibitory concentration: 10600 nM
The estimate for compound 3 lay 1.1-fold (0.05 log units) above the measured number, within the range that was stated.
By their numbers in this assay, from the lowest: compounds 3, 2 and 1 (each within the scatter of the next).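

Compound 3 puts a third kind of substituted phenyl ring on this nitrogen, and 3-chloro-4-fluorophenyl in place of 4-(trifluoromethyl)phenyl gives a 1.1-fold lower number from compound 2 to compound 3 (0.04 log units; within the scatter), while the same ring in place of 2-methylphenyl gives a 1.9-fold lower number from compound 1 to compound 3 (0.28 log units; within the scatter). Until now a single pair stood behind this position; now all three pairs of these compounds agree, and in this assay the 2-methylphenyl, 4-(trifluoromethyl)phenyl and 3-chloro-4-fluorophenyl rings cannot be told apart, so for these three rings, the identity of the substituents makes no readable difference to the number. Nothing available speaks to why these numbers stay so close.

What these compounds leave open is whether any group on this nitrogen would move the number beyond the scatter, for example a phenyl ring carrying a carboxylic acid or a dimethylamino group, or a saturated ring such as a cyclohexyl in place of the phenyl ring. They also leave open whether changes elsewhere on the shared core, such as a longer chain between the sulfur and the amide carbonyl, would matter more than changes at this position.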